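Benzylic acetyl(methyl)amino extension on a non-toxic core

The source may hold more compounds than are shown below. What is called first, only, known or untested is meant among the compounds shown, and "the series" means these compounds.

Compound 1 `Cc1cccc2c1nc(-c1c(F)cccc1F)n2Cc1c(F)cccc1F` is characterised in a toxicity assay on CCRF-CEM cells (Homo sapiens) for cytotoxicity (on this read-out higher numbers stand for lower toxicity in this test and lower numbers for higher toxicity in this test), only by a limit. In this assay compound 1 gives > 100 uM, a limit of the assay rather than a number. Compound 2 `Oc1cccc2c1nc(-c1c(F)cccc1F)n2Cc1c(F)cccc1F` gives > 100 uM in this assay, again a limit. The step that the two limits leave unreadable from compound 1 to compound 2 therefore remains unreadable, as both values sit at the limit of > 100 uM in this assay, at which 2 of the 2 values shown sit. Compound 3 `CC(=O)N(C)Cc1cccc2c1nc(-c1c(F)cccc1F)n2Cc1c(F)cccc1F` carries acetyl(methyl)amino in place of hydrogen on a saturated chain carbon bound to an aromatic carbon. Within the data shown here, no measured step bears readably on this change. For compound 3 a step of a number no higher from compound 1 to compound 3 (the limit leaves the size open) is expected, meaning none beyond the scatter. Compound 3 is estimated at 100 uM, within 30 uM to 300 uM, most likely again a limit.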

Compound 3, half-maximal toxic concentration: 20.6 uM
Beside the measured number, compound 3's estimate is 4.9-fold (0.69 log units) above it; the measured number lies below the stated range.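

In this assay, acetyl(methyl)amino on the saturated chain carbon bound to an aromatic carbon gives an at least 4.8-fold lower number from compound 1 to compound 3 (0.68 log units; beyond the scatter), so a change at this position does register as higher toxicity in this test. Measured against the hydroxy compound, the same extension gives an at least 4.8-fold lower number from compound 2 to compound 3 (0.68 log units; beyond the scatter). Compound 3 is the only one of the three that reads as a number rather than a limit: the limit of > 100 uM in this assay, at which 2 of the 3 values shown sit.

As far as these compounds go, whether the step depends on the acetyl carbonyl or on the whole acetyl(methyl)amino group stays open. A plain dimethylamine or a carboxylic acid on the same carbon would separate these readings.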